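A few compounds are considered here, and "the series" means these few. Any claim that something is new, unique, unknown or untested is made for them only; others in the source may bear on it.

Compound 1 `CNC(=O)c1cc(C(=O)N[C@H]2CC[C@H](O)CC2)c([C@@H](C)c2cccc(F)c2)o1`: >= 63 ug/mL
Compound 2 `CCC(=O)c1c[nH]c(C(=O)NC)c1`: 87 ug/mL
Compound 3 `CNC(=O)c1cc(C(=O)N[C@H]2CC[C@H](O)CC2)c([C@@H](C)c2cccc(C)c2)o1`: >= 172 ug/mL
Compound 4 `CNC(=O)c1cc(C(=O)N[C@H]2CC[C@H](O)CC2)c([C@@H](C)c2ccc(C)cc2)o1`: not yet measured

All of these values come from a physicochemical assay for solubility, measured as kinetic solubility; on this read-out higher numbers stand for higher solubility and lower numbers for lower solubility. Compound 3 gives >= 172 ug/mL, which is a limit and not a number. It stands at the limit of >= 172 ug/mL in this assay, at which 1 of the 3 values shown sits. Compound 1 gives >= 63 ug/mL, which is also a limit. Among the compounds with values here, only compound 2, at 87 ug/mL, has a plain number, and it offers no step to compare.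

Compound 4 differs from compound 3 by one change, with the same atoms joined differently: 4-methylphenyl in place of 3-methylphenyl on a saturated chain carbon bound to an aromatic carbon and a saturated chain carbon. Within the data shown here, the only measured step is a step that the two limits leave unreadable from compound 1 to compound 3. That step concerns a different change and provides no size or direction to carry over. No step beyond the usual scatter is therefore expected, and no direction is favoured. The expected change is an at least 1.0-fold lower number from compound 3 to compound 4 (0.00 log units; that floor lies within the scatter). As far as these compounds go, this expectation is anchored on compound 3 at >= 172 ug/mL, a limit, so the true starting point remains unknown. For compound 4 the estimated value in this assay is 170 ug/mL, with an expected range from 85 ug/mL to 320 ug/mL.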

Compound 4, solubility: >= 245 ug/mL
Compound 4 was reported as a limit; the forecaster's own chance of this, stated with the estimate: 55%; middle value at least 1.4-fold (0.15 log units) from the limit.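

Compound 4 gives >= 245 ug/mL, which is a limit, and so does compound 3 at >= 172 ug/mL and compound 1 at >= 63 ug/mL; no step among these three compounds can be read. As far as these compounds go, whether 3-methylphenyl, 4-methylphenyl or 3-fluorophenyl changes the read-out in this assay, and by how much, stays open.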